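Acetyl on the amine of compound 2

The source may hold more compounds than are shown below. What is called first, only, known or untested is meant among the compounds shown, and "the series" means these compounds.

- compound 1 `CC(=O)Nc1ccc(C(=O)Nc2c(C)cccc2C)cc1`: 4.7 mg/kg
- compound 2 `Cc1cccc(CO)c1NC(=O)c1ccc(N)cc1`: 10.9 mg/kg

In a functional assay on the whole organism with Mus musculus as the target, in the maximal electroshock model (a lower number here means that less compound is needed, a higher number that more compound is needed for the effect), compound 1 gives 4.7 mg/kg and compound 2 stands at 10.9 mg/kg, the higher of the two numbers, and the gap between them lies beyond the scatter. Compound 3 `CC(=O)Nc1ccc(C(=O)Nc2c(C)cccc2CO)cc1` differs from compound 2 by acetyl in place of hydrogen on a nitrogen on an aromatic ring. Among the measured compounds shown here, no measured pair isolates this change. Compound 1 carries an acetamido group and gives 4.7 mg/kg, so a low number remains possible, but a moderate upward step beyond the scatter is expected. The estimated step is a 2.3-fold higher number from compound 2 to compound 3 (0.36 log units; beyond the scatter). For compound 3 the expected value is 25 mg/kg, with an estimated range of 8 mg/kg to 100 mg/kg.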

Compound 3, dose for half-maximal effect: > 100 mg/kg
Compound 3 gave a limit, no number; the forecaster's own chance of this, stated with the estimate: 25%; middle value at least 4.0-fold (0.60 log units) away from the limit.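

In this assay compound 3 stands at a limit of the assay, not a number: the limit of > 100 mg/kg in this assay, at which 1 of the 3 values shown sits. Acetyl in place of hydrogen on this nitrogen gives an at least 9.1-fold higher number from compound 2 to compound 3 (0.96 log units; beyond the scatter), and hydroxy in place of hydrogen on the saturated chain carbon gives an at least 21-fold higher number from compound 1 to compound 3 (1.32 log units; beyond the scatter). Acetamido and hydroxy each occur in a compound with a measured value, so in these compounds the loss appears only where both are present.

From the compounds shown here alone, the true size of both steps stays open beyond the limit. Also open, going by these compounds, is whether methoxy in place of hydroxy, or propionyl in place of acetyl, behaves the same way.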